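From a dioxopiperidine amide to a pyrrolidine amide

This account rests on a few compounds, and the source may have more. Where it says the series, first, only, none or still open, it means among the compounds named here.

- Compound 1 `CC(C)(C)NC(=O)c1c(N)sc(-c2ccc(Cl)cc2)c1-c1ccc(Cl)cc1`: 15100 nM
- Compound 2 `Nc1sc(-c2ccc(Cl)cc2)c(-c2ccc(Cl)cc2)c1C(=O)N1CCC(=O)CC1=O`: 9230 nM

Both values come from a functional assay on PC-3 cells (Homo sapiens) for inhibition, read by sulforhodamine B assay, with a stated time of 72 h; on this read-out lower numbers stand for stronger inhibition and higher numbers for weaker inhibition. Compound 2, at 9230 nM, sits within the usual scatter of compound 1, so neither stands apart. Compound 3 `Nc1sc(-c2ccc(Cl)cc2)c(-c2ccc(Cl)cc2)c1C(=O)N1CCCC1` carries pyrrolidin-1-yl in place of 2,4-dioxopiperidin-1-yl on a carbonyl carbon. Within the data shown here, the only measured step bearing on this change is a 1.6-fold lower number from compound 1 to compound 2 (0.21 log units; within the scatter), made on the same carbonyl carbon. One small step is thin evidence, so no shift beyond the scatter is expected in this assay, in either direction. For compound 3 the estimated value is 10000 nM, with an expected range of 4000 nM to 25000 nM. The expected step is a 1.1-fold higher number from compound 2 to compound 3 (0.03 log units; within the scatter).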

Compound 3, half-maximal inhibitory concentration: 6220 nM
Beside the measured number, compound 3's estimate is 1.6-fold (0.21 log units) above it; the measured number falls inside the stated range.
By their numbers in this assay, from the lowest: compounds 3, 2 and 1 (each within the scatter of the next, the first and the last beyond it).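

On this carbonyl carbon, pyrrolidin-1-yl in place of 2,4-dioxopiperidin-1-yl gives a 1.5-fold lower number from compound 2 to compound 3 (0.17 log units; within the scatter), so in this assay the two ring carbonyls of 2,4-dioxopiperidin-1-yl are not required for the activity seen. Set against the (tert-butyl)amino amide, the same group gives a 2.4-fold lower number from compound 1 to compound 3 (0.39 log units; beyond the scatter), the only step so far to clear the scatter, though only modestly. Nothing available explains this shift. Still open, going by these compounds, is how a morpholine ring or a dimethylamino group on this carbonyl carbon would compare with pyrrolidin-1-yl.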